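Replacing hydroxy with methylamino in compound 2

The source may report more compounds than this note shows. Statements on the series, on what has been measured and on what is new or still open speak of the compounds shown alone.

In a functional assay on A2780 cells (Homo sapiens) for antiproliferative activity, read by MTT assay, with a stated time of 48 h (a higher number here means a weaker inhibitor, a lower number a stronger inhibitor), compound 2 (`COc1ccc(C(=O)c2ccc(OC)c3c2OC(C)(C)C=C3)c(NC(=O)CO)c1`) gives 100 nM. Compound 3 (`COc1ccc(C(=O)c2ccc3c(c2)C=CC(C)(C)O3)c(NC(=O)CO)c1`) gives 130 nM, within the scatter of that value, while compound 1 (`COc1ccc(C(=O)c2ccc(OC)c3c2OC(C)(C)C=C3)c(NC(=O)CBr)c1`) gives 980 nM. Compound 2 therefore sits at the low, more potent end of this small set.

Compound 4 (`CNCC(=O)Nc1cc(OC)ccc1C(=O)c1ccc(OC)c2c1OC(C)(C)C=C2`) changes one place in compound 2: methylamino in place of hydroxy on a saturated chain carbon bound to a carbonyl carbon. In words, methylamino stands in place of hydroxy on a saturated chain carbon bound to a carbonyl carbon.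

Among the measured compounds shown here, only one measured step touches that carbon: a 9.8-fold lower number from compound 1 to compound 2 (0.99 log units; beyond the scatter). For the measured compounds named here, it shows that this assay can respond clearly to a swap there, but that swap involved bromo, and no measured compound carries methylamino. The step therefore offers a guide to size, not a direct precedent. A moderate loss is expected, smaller than that step, and the expected change is a 2.5-fold higher number from compound 2 to compound 4 (0.40 log units; beyond the scatter). For compound 4 the estimated value is 250 nM, with an expected range from 70 nM to 900 nM.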

Compound 4, half-maximal inhibitory concentration: 620 nM
Compound 4: the middle estimate sits 2.5-fold (0.39 log units) below what was measured; measured number inside the range.
By their numbers in this assay, from the lowest: compounds 2 and 3 (each within the scatter of the next); then compounds 4 and 1 (each within the scatter of the next).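

In this assay, moving away from hydroxy on this saturated chain carbon costs activity a second time, with a 6.2-fold higher number from compound 2 to compound 4 (0.79 log units; beyond the scatter) for methylamino, even though both groups are listed with the same hydrogen-bond donor and acceptor counts and no net charge. Bromo and methylamino cannot be told apart, at a 1.6-fold lower number from compound 1 to compound 4 (0.20 log units; within the scatter), so among these three groups hydroxy alone stands apart. No available evidence explains this gap.

From the compounds shown here alone, it remains open whether other groups at this carbon, such as dimethylamino or a longer chain ending in hydroxy, could match hydroxy. It is also unknown whether methylamino would show the same loss on the core of compound 3.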